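The compounds below may be only part of what the source reports. "The series", "measured", "known", "first", "only" and "open" are said of these compounds alone.

Compound 1 `Cc1nc2c3ccccc3ccc2c2nc3c(ccc4ccccc43)c(-c3ccccc3S)c12` carries a 2-sulfanylphenyl on the shared core, and in a functional assay on AGS cells (Homo sapiens) for cytotoxicity, read by MTT assay, with a stated time of 48 h (on this read-out lower numbers stand for stronger inhibition and higher numbers for weaker inhibition), compound 1 gives 4070 nM. Compound 2 `Cc1ccc(-c2c3ccc4ccccc4c3nc3c2c(C)nc2c4ccccc4ccc32)cc1` carries a 4-methylphenyl in the same place instead. In this assay compound 2 reaches only a limit of the assay, > 80000 nM, not a number. That single exchange therefore brought an at least 19-fold higher number from compound 1 to compound 2 (1.29 log units; beyond the scatter), and the size of this step is set by the limit of > 80000 nM in this assay, at which 1 of the 2 values shown sits.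

Compound 3 `Cc1nc2c3ccccc3ccc2c2nc3c(ccc4ccccc43)c(-c3ccccc3N)c12` differs from compound 2 in that (2-aminophenyl in place of 4-methylphenyl on an aromatic carbon). Within the data shown here, a 2-aminophenyl resembles the 2-sulfanylphenyl of compound 1 more than it resembles a 4-methylphenyl, so the one measured step that bears on this change is the large one from compound 1 to compound 2, now run in the opposite sense. A large fall in the number is expected: the expected step is an at least 13-fold lower number from compound 2 to compound 3 (1.12 log units; beyond the scatter). Compound 3 is thus estimated to give 6000 nM, with a likely range from 1500 nM to 40000 nM.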

Compound 3, half-maximal inhibitory concentration: 12100 nM
Compound 3: middle estimate off by 2.0-fold (0.30 log units), on the low side; the range from low to high includes it.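

Among these compounds, putting a 2-aminophenyl on the shared core brings back measurable cytotoxicity in this assay, with an at least 6.6-fold lower number from compound 2 to compound 3 (0.82 log units; beyond the scatter), so the 2-sulfanylphenyl of compound 1 is not the only group at this place that gives a number. From the compounds shown here alone, the true size of that step remains unknown, and what sets its reported size is this: the limit of > 80000 nM in this assay, at which 1 of the 3 values shown sits. The two groups are also not interchangeable, since amino in place of sulfanyl gives a 3.0-fold higher number from compound 1 to compound 3 (0.47 log units; beyond the scatter), which shows that the identity of the group on the phenyl ring matters here.

The compounds shown leave open whether the group itself or its place on the phenyl ring counts for more. A 4-aminophenyl and a 2-hydroxyphenyl on the same core would help to separate these two possibilities.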